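Series notes: sulfanyl in place of oxiran-2-yl

This account rests on a few compounds, and the source may have more. Where it says the series, first, only, none or still open, it means among the compounds named here.

Compound 3 `FC(F)(F)c1cc(C2CO2)cc(C(F)(F)F)c1` gives 6 h in an ADME assay for pharmacokinetics, read by HPLC, in phosphate buffer, with a stated time of 72 h, at pH 7.4, tested at 250 uM (on this read-out lower numbers stand for a shorter-lived compound and higher numbers for a longer-lived compound), and stands as the higher of the two numbers in hand, though compound 1 `C=CC(=O)Nc1cc(C(F)(F)F)cc(C(F)(F)F)c1` with 4.2 h lies within the scatter of it. Compound 2 `O=C(CBr)c1cc(C(F)(F)F)cc(C(F)(F)F)c1` is reported in this assay only as a limit, < 0.017 h. The measured steps are a 1.4-fold higher number from compound 1 to compound 3 (0.15 log units; within the scatter), which is within the scatter, and an at least 350-fold higher number from compound 2 to compound 3 (2.54 log units; beyond the scatter), which is large, as is an at least 240-fold lower number from compound 1 to compound 2 (2.39 log units; beyond the scatter).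

Compound 4 `FC(F)(F)c1cc(S)cc(C(F)(F)F)c1` differs from compound 3 by sulfanyl in place of oxiran-2-yl on an aromatic carbon. Among the measured compounds shown here, none of the measured steps exchanges the oxiran-2-yl group for a sulfanyl group, so they bear on this change only loosely: they show that the shared core carries groups spanning a very wide range of half-lives. The expected step is a modest shortening, a 2.0-fold lower number from compound 3 to compound 4 (0.30 log units; within the scatter), with uncertainty in both directions. Compound 4 is therefore estimated at 3 h in this assay, with a range from 0.5 h to 20 h.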

Compound 4, half-life: 31.5 h
Estimate against measurement, compound 4: 11-fold (1.02 log units) below, and the stated range ends below it.
By their numbers in this assay, from the lowest: compounds 1 and 3 (each within the scatter of the next); then compound 4. At a limit, below all of these: compound 2.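

At this aromatic carbon, meta to two trifluoromethyl groups, the choice of group separates half-lives that earlier looked level: sulfanyl gives a 5.3-fold higher number from compound 3 to compound 4 (0.72 log units; beyond the scatter) and a 7.5-fold higher number from compound 1 to compound 4 (0.88 log units; beyond the scatter), both beyond the scatter, so compound 4 is the longest-lived of the compounds shown in this assay. Among the compounds shown here, the earlier oxiran-2-yl and (vinylcarbonyl)amino groups lay within the scatter of each other, so the sulfanyl exchange is the first to rise clearly above both. Compound 2 remains a limit, and an at least 1800-fold higher number from compound 2 to compound 4 (3.26 log units; beyond the scatter) is therefore a bound and not a measured gap: the limit of < 0.017 h in this assay, at which 1 of the 4 values shown sits.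

Nothing in the data shown gives a cause for the longer half-life of compound 4. As far as these compounds go, how a hydroxyl group, an amine or a methylsulfanyl group on the same aromatic carbon would compare with sulfanyl remains open.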